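Removing a methoxy group from a methyltransferase inhibitor

The source may report more compounds than this note shows. Statements on the series, on what has been measured and on what is new or still open speak of the compounds shown alone.

Measured compounds:
- compound 1, `COc1ccccc1-c1nnc2sc(/C=C/c3ccco3)nn12`: 78%
- compound 2, `c1ccc2c(Cc3nn4c(-c5ccoc5)nnc4s3)cccc2c1`: 77%

In an assay for inhibition of histone-lysine N-methyltransferase, H3 lysine-79 specific (Homo sapiens), read by scintillation counting, with stated times of 15 min and 60 min, tested at 100 uM, in the presence of a further agent that is not named here (on this read-out lower numbers stand for a weaker effect and higher numbers for a stronger effect at the one concentration tested), compound 1 gives 78%. For the measured compounds named here, compound 2 gives 77% in this assay, and the two numbers lie within the scatter of each other, so neither compound can be placed above the other; compound 1 simply stands together with compound 2 on the only two numbers known. Going by the values given here, no single-point step between them is available, because the two structures differ in more than one place.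

Compound 3, `C(=C/c1nn2c(-c3ccccc3)nnc2s1)\c1ccco1`, is not yet measured. It differs from compound 1 in one place: hydrogen in place of methoxy on an aromatic carbon. Among the compounds with values here, no measured pair shows what such a change does here, so the size of the step is unknown; a modest weakening, perhaps no larger than the scatter, is the expectation. Compound 3 is therefore estimated at 70% in this assay, between 45% and 90%, an expected step of a number 8 percentage points lower from compound 1 to compound 3 (within the scatter).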

Compound 3, a percentage reported as inhibition, at one concentration (the size of the read-out at that concentration, not a potency): 81%
Compound 3: the middle estimate sits 11 percentage points below what was measured; measured number inside the range.
By their numbers in this assay, from the lowest: compounds 2, 1 and 3 (each within the scatter of the next).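

In this assay, for the compounds shown here, hydrogen in place of methoxy gives a number 3 percentage points higher from compound 1 to compound 3 (within the scatter), which is the first comparison here of two compounds that differ in one place. At the single concentration tested, the methoxy group on this aromatic carbon, ortho to a large group, can therefore be lost, along with its 2 heavy atoms and its hydrogen-bond acceptor, without a step that stands out from the scatter. No measurement shown bears on the reason for this result.

The compounds shown leave open what other groups on this carbon would do, such as an amine, a carboxylic acid or a longer chain like butoxy. A read-out at one concentration is also not a potency, so whether compound 1 and compound 3 would separate at lower concentrations remains an open question.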